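Biphenyl group entering a cytotoxicity series

The source may hold more compounds than are shown below. What is called first, only, known or untested is meant among the compounds shown, and "the series" means these compounds.

Compound 1 `CC1(Cc2cccc([N+](=O)[O-])c2)CC(S(=O)(=O)c2ccc(F)cc2)=C(c2ccc(/C(N)=N/O)cc2)O1`: 86600 nM
Compound 2 `Cc1cccc(CC2(C)CC(S(=O)(=O)c3ccc(F)cc3)=C(c3ccc(/C(N)=N/O)cc3)O2)c1`: 112000 nM

Both numbers come from an ADME assay on cells (Peritoneal macrophage, Mus musculus, strain Balb/c) for cytotoxicity, read by resazurin assay, with a stated time of 72 h; a lower number here means that less compound is tolerated, a higher number that more compound is tolerated. Compound 2 and compound 1 lie within the scatter of each other, and the step of a 1.3-fold higher number from compound 1 to compound 2 (0.11 log units; within the scatter) does not separate them. Compound 3 `CC1(Cc2ccc(-c3ccccc3)cc2)CC(S(=O)(=O)c2ccc(F)cc2)=C(c2ccc(/C(N)=N/O)cc2)O1` is not yet measured. It differs from compound 2 by 4-phenylphenyl in place of 3-methylphenyl on a saturated chain carbon bound to a saturated ring carbon. Within the data shown here, the only measured step, a 1.3-fold higher number from compound 1 to compound 2 (0.11 log units; within the scatter), also altered the group on this chain carbon and gave nothing beyond the scatter, but it exchanged one single-ring group for another, whereas here a second aromatic ring enters. Among the measured compounds shown here, no measured step covers such a change, so the expectation rests on the two values alone, and the expected step of a 1.2-fold lower number from compound 2 to compound 3 (0.07 log units; within the scatter) is kept close to zero with a wide range. For compound 3 the estimate in this assay is 95000 nM, between 35000 nM and 250000 nM.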

Compound 3, half-maximal cytotoxic concentration: 33900 nM
Estimate against measurement, compound 3: 2.8-fold (0.45 log units) above; measured number below the stated range.
By their numbers in this assay, from the lowest: compound 3; then compounds 1 and 2 (each within the scatter of the next).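

In this assay, the saturated chain carbon bound to a saturated ring carbon now proves able to shift the number: 4-phenylphenyl in place of 3-methylphenyl gives a 3.3-fold lower number from compound 2 to compound 3 (0.52 log units; beyond the scatter), and 4-phenylphenyl in place of 3-nitrophenyl gives a 2.6-fold lower number from compound 1 to compound 3 (0.41 log units; beyond the scatter). Both steps are modest but lie beyond the scatter, whereas exchanging one single-ring group for another did not separate compound 1 from compound 2. No measurement shown here accounts for why less of compound 3 is tolerated.

Only compound 3 carries a second aromatic ring, so these compounds cannot tell whether that ring or simply a group with more heavy atoms goes with the lower number. Also open, on these data alone, is how the number would respond to a cyclohexyl group, an amine or a carboxylic acid at this place.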